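The compounds below may be only part of what the source reports. "The series", "measured", "known", "first", "only" and "open" are said of these compounds alone.

Working notes on the series. The three measured compounds share one core carrying a sulfonyl-linked aryl group and a methylpiperidine. Compound 1 `COc1ccc2ncc(S(=O)(=O)c3ccc(Cl)c(Cl)c3)c(N3CCC(C)CC3)c2c1`, compound 2 `CC1CCN(c2c(S(=O)(=O)c3ccc(F)c(F)c3)cnc3cc(Cl)ccc23)CC1` and compound 3 `CC1CCN(c2c(S(=O)(=O)c3ccc(F)c(F)c3)cnc3cc(F)ccc23)CC1` have been run in an assay on isolated protein for displacement of a labelled ligand from metabotropic glutamate receptor 5 (Homo sapiens), with a stated time of 60 min, tested at 1 uM; on this read-out higher numbers stand for more inhibition at the one concentration tested (going by the name of the read-out) and lower numbers for less inhibition. In this assay compound 2 gives 90%; compound 1 gives 87% and compound 3 gives 94%, and all three values lie within the usual scatter of one another, so no ordering among them can be read from the numbers.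

Compound 4 `COc1ccc(S(=O)(=O)c2cnc3cc(Cl)ccc3c2N2CCC(C)CC2)cc1` is not yet measured. It differs from compound 2 by 4-methoxyphenyl in place of 3,4-difluorophenyl on a sulfonyl sulfur. Among the compounds with values here, the only single-point step measured so far, a number 4 percentage points higher from compound 2 to compound 3 (within the scatter), concerns the halogen on the core, not the aryl on the sulfonyl sulfur, and it stayed within the scatter. Compound 1 also carries a different sulfonyl aryl than compound 2, but it differs from compound 2 in more than one place, so its value and that of compound 2 show only that both sit in the same narrow band. Within the data shown here, no measured step therefore bears directly on the change to compound 4.

Given the tightly grouped values of compounds 1, 2 and 3, compound 4 is expected to give 80% in this assay, in the range 55% to 95%. The expected step is a number 10 percentage points lower from compound 2 to compound 4 (within the scatter), with the lower centre reflecting the absence of any measured change at this position rather than a trend in the data.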

Compound 4, a percentage reported as inhibition, at one concentration (the size of the read-out at that concentration, not a potency): 79%
Beside the measured number, compound 4's estimate is 1 percentage points above it; measured number inside the range.
By their numbers in this assay, from the lowest: compounds 4, 1, 2 and 3 (each within the scatter of the next, the first and the last beyond it).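

In this assay, within the data shown here, the swap of 3,4-difluorophenyl for 4-methoxyphenyl on the sulfonyl sulfur gives a number 11 percentage points lower from compound 2 to compound 4 (beyond the scatter) and is the only single-place step so far that lies beyond the scatter, though it is modest. The halogen change on the core, by comparison, gives a number 4 percentage points higher from compound 2 to compound 3 (within the scatter) and so shows no readable effect, which leaves the aryl on the sulfonyl sulfur as the one position where the read-out has been seen to respond to a change. Both groups have the same count of heavy atoms and one six-membered aromatic ring of carbon only, but nothing measured explains the step, and the data offer no account of why this exchange lowers the number.

The compounds shown do not separate the entry of the methoxy group from the departure of the two fluorines, and an unsubstituted phenyl or a pyridine ring on the sulfonyl sulfur would bear on that. Also open, as far as these compounds go, is what a morpholine or a piperazine in place of the methylpiperidine would do, and all these readings rest on inhibition at one concentration, which is not a potency.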